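The source may hold more compounds than are shown below. What is called first, only, known or untested is meant among the compounds shown, and "the series" means these compounds.

In a functional assay on HCT-116 cells (Homo sapiens) for cytotoxicity, read by MTT assay, with a stated time of 72 h (a higher number here means a weaker inhibitor, a lower number a stronger inhibitor), compound 1 `O=C(Nc1ccc(Cl)cc1)Nc1ccc(C(=O)NO)cc1` gives > 50000 nM, which is a limit of the assay and not a number. Going by the values given here, compound 2 `O=C(CCc1ccc(NC(=O)Nc2ccccc2)cc1)NO` gives 16200 nM, the only true number so far, so it stands without a numerical neighbour for comparison. Compound 3 `O=C(CCc1ccc(NC(=O)Nc2ccc(Cl)cc2)cc1)NO` keeps the structure of compound 2 except in one place, where phenyl becomes 4-chlorophenyl: chloro in place of hydrogen on an aromatic carbon. The new chloro group stands on an aromatic carbon, para to a large group. Among the compounds with values here, no measured pair isolates this change, so the expectation is tentative: a small step towards a stronger inhibitor in this assay. The expected change is a 2.3-fold lower number from compound 2 to compound 3 (0.36 log units; beyond the scatter). For compound 3 the estimated value is 7000 nM, with an expected range from 2500 nM to 20000 nM.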

Compound 3, half-maximal inhibitory concentration: 17900 nM
Estimate against measurement, compound 3: 2.6-fold (0.41 log units) below; the measured number falls inside the stated range.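

In this assay, chloro in place of hydrogen on this aromatic carbon, para to a large group, gives a 1.1-fold higher number from compound 2 to compound 3 (0.04 log units; within the scatter), so the position takes the chloro group with no readable change in the number. With the chloro group held in place, 2-(hydroxycarbamoyl)ethyl in place of hydroxycarbamoyl gives an at least 2.7-fold lower number from compound 1 to compound 3 (0.44 log units; beyond the scatter), so among these compounds the one step beyond the scatter comes from that change and not from the chloro group. The value of compound 1 is a limit and not a number, so the size of that step has only a lower bound: the limit of > 50000 nM in this assay, at which 1 of the 3 values shown sits.

As far as these compounds go, whether an amine, a methoxy group or a carboxylic acid at this position would move the number remains open. Also open, from the compounds shown here alone, is what a longer chain in place of 2-(hydroxycarbamoyl)ethyl would do.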